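The compounds below may be only part of what the source reports. "The series", "measured", "known", "first", "only" and "open" are said of these compounds alone.

Working notes on the series. In a functional assay on the whole organism for positive allosteric modulation, with Mus musculus as the target (on this read-out lower numbers stand for an effect already at smaller amounts and higher numbers for an effect only at larger amounts of compound), compound 1 `CCC(=O)N(c1ccc(Cl)c(Cl)c1)C1CCCC1O` gives 0.4 mg/kg, the lowest of the two numbers measured. Compound 3 `CCC(=O)N(c1cc(Cl)c(Cl)c(Cl)c1)C1CCCC1N(C)C` gives 4 mg/kg, a higher number and a gap beyond the usual scatter. Compound 2 `CCC(=O)N(c1ccc(C)cc1)C1CCCCC1N(C)C` gives > 50 mg/kg, which is a limit of this assay and not a number; the series therefore contains (the limit of > 50 mg/kg in this assay, at which 1 of the 3 values shown sits). Compound 4 `CCC(=O)N(c1ccc(Cl)c(Cl)c1)C1CCCC1N(C)CCCN(C)C` is not yet measured. It differs from compound 1 by (3-(dimethylamino)propyl)(methyl)amino in place of hydroxy on a saturated ring carbon. Within the data shown here, no measured pair shows this change, so the step is judged from the spread of the series alone: a move toward higher numbers is expected, a 7.5-fold higher number from compound 1 to compound 4 (0.88 log units; beyond the scatter), since compound 3 with its amino substituent gives 4 mg/kg. Compound 4 is estimated at 3 mg/kg, within a range of 0.5 mg/kg to 20 mg/kg.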

Compound 4, dose for half-maximal effect: 4 mg/kg
Estimate against measurement, compound 4: 1.3-fold (0.12 log units) below; the measured number falls inside the stated range.
By their numbers in this assay, from the lowest: compound 1; then compounds 3 and 4 (each within the scatter of the next). At a limit, above all of these: compound 2.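

In this assay, among these compounds, (3-(dimethylamino)propyl)(methyl)amino in place of hydroxy on a saturated ring carbon gives a 10-fold higher number from compound 1 to compound 4 (1.00 log units; beyond the scatter), the first change that can be read at one place with the core of compound 1 held constant. Compound 4 still gives a number, 4 mg/kg, and not a limit. The data shown give no cause for this step.

From the compounds shown here alone, whether the step follows from losing the hydroxy or from adding the long chain stays open. A methoxy or a primary amine on the same ring carbon would separate the two.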